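The compounds below may be only part of what the source reports. "The series", "measured", "known", "first", "only" and "open" are said of these compounds alone.

Measured so far in an ADME assay on a cell-free system (plasma, Rattus norvegicus) for protein binding
- Compound 1 `CNc1nccc(N2CC[C@H](NC(=O)Nc3cccc(C#N)c3)C2)n1` gives 91.6%
- Compound 2 `CNc1nccc(N2CC[C@H](NC(=O)Nc3ccc(OC)cc3)C2)n1` gives 86.3%
- Compound 3 `CNc1nccc(N2CC[C@H](NC(=O)Nc3ccc(OC(F)F)cc3)C2)n1` gives 97.7%

Two steps place compound 2 among these. The first, a 1.6-fold higher unbound fraction from compound 1 to compound 2 (0.21 log units; within the scatter), leaves compound 2 indistinguishable from compound 1. The second, a 6.0-fold lower unbound fraction from compound 2 to compound 3 (0.77 log units; beyond the scatter), sets compound 3 clearly apart.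

Compound 4 `CNc1nccc(N2CC[C@H](NC(=O)Nc3cccc(OC)c3)C2)n1` has the same atoms as compound 2, joined differently. The change 3-methoxyphenyl in place of 4-methoxyphenyl on an amide-type nitrogen is 3-methoxyphenyl in place of 4-methoxyphenyl on an amide-type nitrogen.

Going by the values given here, no measured pair shows this exact change. The closest guide is the swap at that same nitrogen, where the step a 1.6-fold higher unbound fraction from compound 1 to compound 2 (0.21 log units; within the scatter) stayed small even though the group itself was exchanged. The step to compound 3 concerns the group on the oxygen instead, so it says little here.

In this assay no shift beyond the scatter is therefore expected, and the estimated change is a 1.1-fold lower unbound fraction from compound 2 to compound 4 (0.06 log units; within the scatter) in this case. Compound 4 is expected to read 88%, with an estimated range from 78% to 94% overall.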

Compound 4, plasma protein binding: 93.9%
For compound 4 the middle estimate is 2.0-fold (0.29 log units) (unbound fraction) above the measured one; low and high end bracket the measured number.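

In this assay, the swap of 4-methoxyphenyl for 3-methoxyphenyl on the amide-type nitrogen gives a 2.2-fold lower unbound fraction from compound 2 to compound 4 (0.35 log units; beyond the scatter) even though no atom is gained or lost, so at this position the way the same atoms are joined can count on its own. Methoxy in place of cyano on an aromatic carbon gives a 1.4-fold lower unbound fraction from compound 1 to compound 4 (0.14 log units; within the scatter) and so stays inside the usual scatter, while the move of the methoxy does not. The data give no measured reason for the shift between compound 2 and compound 4.

Still open, going by these compounds, is whether moving another group would give a similar step, such as 3-difluoromethoxyphenyl in place of the 4-difluoromethoxyphenyl of compound 3. Also open is how an amine or a carboxylic acid on this ring would read, since neither appears among these compounds.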